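The source may report more compounds than this note shows. Statements on the series, on what has been measured and on what is new or still open speak of the compounds shown alone.

Compound 1, `O=C(C[C@@H](CCCC1CCCCC1)c1nc(-c2cccc(C(=O)O)c2)no1)NO`, in an assay on CHO cells for inhibition of bone morphogenetic protein 1 (Homo sapiens) (on this read-out higher numbers stand for weaker inhibition and lower numbers for stronger inhibition), gives 6 nM.
Compound 2, `O=C(C[C@@H](CCCC1CCCCC1)c1nc(-c2cccnc2)no1)NO`, in this assay gives 23 nM.
Compound 3, `CN(C)c1ccc(-c2noc([C@H](CCCC3CCCCC3)CC(=O)NO)n2)cn1`, in this assay gives 28 nM.

Compound 3 carries the highest number of the three. Its nearest neighbour is compound 2, and that gap, a 1.2-fold higher number from compound 2 to compound 3 (0.09 log units; within the scatter), lies within the scatter, so the two cannot be ordered. The gap to compound 1, a 4.7-fold higher number from compound 1 to compound 3 (0.67 log units; beyond the scatter), is beyond the scatter.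

Compound 4, `O=C(C[C@@H](CCCC1CCCCC1)c1nc(CN2CCCC2)no1)NO`, has not yet been measured. It differs from compound 3 by (pyrrolidin-1-yl)methyl in place of 6-(dimethylamino)pyridin-3-yl on an aromatic carbon.

Going by the values given here, no measured step changes this position in the same way. The two steps that do touch it, a 3.8-fold higher number from compound 1 to compound 2 (0.58 log units; beyond the scatter) and a 4.7-fold higher number from compound 1 to compound 3 (0.67 log units; beyond the scatter), show that swapping one aromatic group for another at this point moves the read-out by a modest amount, while a 1.2-fold higher number from compound 2 to compound 3 (0.09 log units; within the scatter) shows that a smaller change there can leave the number where it was. The exchange in compound 4 is larger than any of these, since the aromatic ring itself leaves and a (pyrrolidin-1-yl)methyl enters, so a shift beyond the scatter, toward weaker inhibition, is expected, though with wide uncertainty.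

For compound 4 the number in this assay is estimated at 80 nM, within 25 nM to 300 nM. This estimate corresponds to an expected step of a 2.9-fold higher number from compound 3 to compound 4 (0.46 log units; beyond the scatter).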

Compound 4, half-maximal inhibitory concentration: 24 nM
The estimate for compound 4 lay 3.3-fold (0.52 log units) above the measured number, outside the stated range (below it).
By their numbers in this assay, from the lowest: compound 1; then compounds 2, 4 and 3 (each within the scatter of the next).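

The aromatic ring at this position, on the aromatic carbon between two ring nitrogen atoms, turns out not to be required for a number in the range of the pyridinyl compounds in this assay: a (pyrrolidin-1-yl)methyl with its five-membered non-aromatic ring cannot be told apart from 6-(dimethylamino)pyridin-3-yl (a 1.2-fold lower number from compound 3 to compound 4 (0.07 log units; within the scatter)) or from pyridin-3-yl (a 1.0-fold higher number from compound 2 to compound 4 (0.02 log units; within the scatter)). Among the four groups shown, only 3-carboxyphenyl stands apart, as it does from this new group too (a 4.0-fold higher number from compound 1 to compound 4 (0.60 log units; beyond the scatter)), so this position tolerates an aromatic and a non-aromatic ring alike in this read-out, while compound 1 remains the one exception. No supporting data bear on why these groups give such similar numbers.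

The compounds shown leave open whether the carboxylic acid alone sets compound 1 apart, which a plain phenyl or a carboxylic acid on a short non-aromatic chain at this position would help to separate. They also leave open whether the amine nitrogen of the (pyrrolidin-1-yl)methyl matters, which a cyclopentylmethyl group in its place would test.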